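The source may hold more compounds than are shown below. What is called first, only, known or untested is meant among the compounds shown, and "the series" means these compounds.

In a functional assay on Bel7402/5-FU cells (Homo sapiens) for antiproliferative activity, read by MTT assay, with a stated time of 72 h (a higher number here means a weaker inhibitor, a lower number a stronger inhibitor), compound 1 `COc1cccc(CNCc2c(C(=O)O)n(Cc3ccc(O)cc3)c3cc(C(C)C)ccc23)c1` gives > 50000 nM, which is a limit and not a number. Compound 3 `COc1cccc(CNCc2c(C(=O)O)n(Cc3ccc(N)cc3)c3cc(C(C)C)ccc23)c1` gives > 50000 nM, again only a limit. That is the limit of > 50000 nM in this assay, at which 2 of the 3 values shown sit, so compound 3 has no readable position on the scale. Among the measured compounds shown here, compound 2 `COc1ccc(Cn2c(C(=O)O)c(CNCc3ccc(O)c(OC)c3)c3ccc(C(C)C)cc32)cc1` gives 7900 nM, the only true number in the set, though no single-place step ties compound 2 to the other two.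

The next change leads to compound 4 `COc1cccc(CNCc2c(C(=O)O)n(Cc3ccccc3F)c3cc(C(C)C)ccc23)c1`: 2-fluorophenyl in place of 4-aminophenyl on a saturated chain carbon bound to an aromatic nitrogen. In words, 2-fluorophenyl stands in place of 4-aminophenyl on a saturated chain carbon bound to an aromatic nitrogen.

For the measured compounds named here, the one measured step at this same group is a step that the two limits leave unreadable from compound 1 to compound 3. It has no readable size, so it sets no figure for the new change. Going by the values given here, it shows only that this group was altered once without the result leaving the limit. The expectation is therefore loose: compound 4 should stay weak, close to the limit, with a fair chance of being reported only as a limit. Some move toward the stronger side remains possible, given compound 2 at 7900 nM. The expected change is an at least 1.4-fold lower number from compound 3 to compound 4 (0.15 log units; that floor lies within the scatter), and its size is poorly fixed. Compound 4 is estimated at 35000 nM, with an expected range of 10000 nM to 90000 nM.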

Compound 4, half-maximal inhibitory concentration: 5210 nM
The estimate for compound 4 lay 6.7-fold (0.83 log units) above the measured number; measured number outside the range, below it.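

In this assay compound 4 gives 5210 nM, a true number. So the group on the saturated chain carbon bound to an aromatic nitrogen can give a true number, which the earlier compounds at this place did not show: the change to 2-fluorophenyl gives an at least 9.5-fold lower number from compound 3 to compound 4 (0.98 log units; beyond the scatter), and it gives an at least 9.5-fold lower number from compound 1 to compound 4 (0.98 log units; beyond the scatter). The same result appears from both the 4-aminophenyl and the 4-hydroxyphenyl starting points, while the earlier step between those two groups cannot be read. Both new steps fix only a smallest size and not a true size, because compound 1 and compound 3 each stand at a limit, not at a number: the limit of > 50000 nM in this assay, at which 2 of the 4 values shown sit.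

The change replaces the 4-substituted ring with a 2-substituted one and also exchanges the amino or hydroxy group for fluorine, so the compounds shown cannot say which of these matters; an unsubstituted phenyl and a 4-fluorophenyl at this place would separate the two. Also open is whether a chloro or methoxy group on the same ring would serve as 2-fluorophenyl does here, since fluorine is the only halogen among the compounds shown.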